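Swapping the aryl amide in a thiazole acylurea series

This account rests on a few compounds, and the source may have more. Where it says the series, first, only, none or still open, it means among the compounds named here.

Measured so far:
- compound 1, `CN(C(=O)NC(=O)c1ccc(Cl)cc1Cl)c1nc(C(F)(F)F)c(C(=O)N/N=C/c2ccc(C(F)(F)F)cc2)s1`: 8.42 ug/mL
- compound 2, `CNc1nc(C)c(C(=O)N/N=C/c2cccc(C(F)(F)F)c2)s1`: > 100 ug/mL
- compound 3, `CN(C(=O)NC(=O)c1ccc(F)c(F)c1)c1nc(C(F)(F)F)c(C(=O)N/N=C/c2cc(C(F)(F)F)cc(C(F)(F)F)c2)s1`: 2.61 ug/mL

All three compounds were tested in a functional assay on MCF7 cells (Homo sapiens) for inhibition, read by MTT assay, with a stated time of 72 h; a higher number here means a weaker inhibitor, a lower number a stronger inhibitor. In this assay compound 3 gives 2.61 ug/mL, the lowest of the two numbers that were recorded. The nearest number belongs to compound 1, which gives 8.42 ug/mL, a gap that lies beyond the usual scatter of this assay. Compound 2, which lacks the acylurea chain and carries a methyl group on its core, reaches only the limit of the assay, > 100 ug/mL; this is the limit of > 100 ug/mL in this assay, at which 1 of the 3 values shown sits, and not a measured number. No two of the measured compounds differ in one place only, so no single structural step can be read from them.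

Compound 4, `CN(C(=O)NC(=O)c1ccc(C(F)(F)F)cc1)c1nc(C(F)(F)F)c(C(=O)N/N=C/c2cc(C(F)(F)F)cc(C(F)(F)F)c2)s1`, has not yet been measured. It differs from compound 3 by 4-(trifluoromethyl)phenyl in place of 3,4-difluorophenyl on a carbonyl carbon. Among the compounds with values here, both groups are fluorinated aromatic rings on the same carbonyl carbon, and nothing among the measured compounds shows how this kind of swap moves the number. The step of a 1.1-fold higher number from compound 3 to compound 4 (0.06 log units; within the scatter) is therefore expected to stay within the scatter, with no direction favoured. Compound 4 is expected to give about 3 ug/mL, between 1 ug/mL and 9 ug/mL.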

Compound 4, half-maximal inhibitory concentration: 7.37 ug/mL
Estimate against measurement, compound 4: 2.5-fold (0.39 log units) below; the range from low to high includes it.
By their numbers in this assay, from the lowest: compound 3; then compounds 4 and 1 (each within the scatter of the next). At a limit, above all of these: compound 2.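

In this assay, within the data shown here, the change of 4-(trifluoromethyl)phenyl in place of 3,4-difluorophenyl gives a 2.8-fold higher number from compound 3 to compound 4 (0.45 log units; beyond the scatter) and is the first step in this set that can be read at a single place, on a carbonyl carbon whose other neighbour is an amide-type nitrogen. The step is modest but beyond the scatter, so these two fluorinated aromatic rings are not interchangeable here, and the group at this place can change the number even when the rest of the molecule stays the same. The two groups share the same kind of ring, with no hydrogen-bond donors or acceptors and no net charge, and differ in their carbon and fluorine counts, but no measurement shown explains why the number moved.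

This single step cannot show whether the swap would move the number in the same direction and by a similar amount if the other end of the molecule were different. It also leaves open how the number would respond to a plain phenyl ring, or to a phenyl ring carrying a methoxy group or an amine, at this place.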